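Adding a Methoxy Group to the Hydrazone Phenol Ring

The compounds below may be only part of what the source reports. "The series", "measured", "known", "first", "only" and "open" are said of these compounds alone.

Compound 2 `Oc1ccccc1/C=N/Nc1cnc2ccccc2n1` was tested in a functional assay on SF-295 cells (Homo sapiens) for inhibition, read by MTT assay (a higher number here means a weaker inhibitor, a lower number a stronger inhibitor), and gave 2310 nM. Among the measured compounds shown here, of the two numbers so far, compound 2 holds the higher one, but the only other compound, compound 1 `O=[N+]([O-])c1ccc(O)c(/C=N/Nc2cnc3ccccc3n2)c1`, gave 2110 nM in this assay, and the step of a 1.1-fold higher number from compound 1 to compound 2 (0.04 log units; within the scatter) stays within the scatter, so the two cannot be told apart.

Compound 3 `COc1ccc(/C=N/Nc2cnc3ccccc3n2)c(O)c1` has not been measured yet. It differs from compound 2 by methoxy in place of hydrogen on an aromatic carbon. For the measured compounds named here, the only measured step, a 1.1-fold higher number from compound 1 to compound 2 (0.04 log units; within the scatter), exchanged a different group on the same ring and lay within the scatter; it bears on the new change only loosely, and no measured pair adds a methoxy group. On that footing no step beyond the scatter is expected for compound 3, which would be a change of a 1.0-fold lower number from compound 2 to compound 3 (0.00 log units; within the scatter). In this assay compound 3 is therefore estimated at 2300 nM, with a likely range from 1000 nM to 5500 nM.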

Compound 3, half-maximal inhibitory concentration: 15700 nM
For compound 3 the middle estimate is 6.8-fold (0.83 log units) below the measured one; the whole stated range lies below it.
By their numbers in this assay, from the lowest: compounds 1 and 2 (each within the scatter of the next); then compound 3.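

Placing a methoxy group in place of hydrogen on this aromatic carbon, meta to the hydroxy group and para to the large group, gives the first change in this assay that lies beyond the scatter, a 6.8-fold higher number from compound 2 to compound 3 (0.83 log units; beyond the scatter). This carbon is therefore not indifferent to what sits on it: here the added methoxy group goes with weaker inhibition, whereas the exchange of nitro for hydrogen, a 1.1-fold higher number from compound 1 to compound 2 (0.04 log units; within the scatter), stayed within the scatter. Nothing available explains why the methoxy group has this effect.

Going by these compounds, whether any added group at this carbon weakens inhibition or the methoxy group is a special case remains open, and a methyl group, a fluorine atom or an amine here would help separate the two. Also open, on these data alone, is whether a longer ether chain, such as ethoxy, would weaken inhibition further.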